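Swapping Hydroxy for Chloro in a Growth Inhibition Series

This account rests on a few compounds, and the source may have more. Where it says the series, first, only, none or still open, it means among the compounds named here.

In a functional assay on NCI-H460 cells (Homo sapiens) for cytotoxicity, read by sulforhodamine B assay (on this read-out higher numbers stand for weaker inhibition of growth and lower numbers for stronger inhibition of growth), compound 1 `CC1=CC[C@@H]([C@@](C)(O)CCCC(C)(C)NC=S)CC1` reaches only a limit of the assay, > 100000 nM. Among the compounds with values here, compound 2 `CC1=CC[C@@H]([C@@](C)(O)CCCC(C)(C)NC(=S)N/N=C\c2ccc(O)cc2)CC1` gives 20700 nM, the only actual number so far in this assay. Compound 3 `CC1=CC[C@@H]([C@@](C)(O)CCCC(C)(C)NC(=S)N/N=C\c2ccc(Cl)cc2)CC1` differs from compound 2 at one place, with chloro in place of hydroxy on an aromatic carbon, para to a large group (chloro in place of hydroxy on an aromatic carbon). Within the data shown here, no measured pair yet shows what this exchange does, so the expected step of a 1.2-fold lower number from compound 2 to compound 3 (0.06 log units; within the scatter) is none beyond the usual scatter. For compound 3 the estimated value in this assay is 18000 nM, with an expected range from 7000 nM to 50000 nM.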

Compound 3, concentration for total growth inhibition: > 100000 nM
Compound 3 was reported as a limit; the forecaster's own chance of this, stated with the estimate: 12%; middle value at least 5.5-fold (0.74 log units) away from the limit.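

At the aromatic carbon para to a large group, chloro in place of hydroxy is not a silent exchange in this assay: it gives an at least 4.8-fold higher number from compound 2 to compound 3 (0.68 log units; beyond the scatter). Compound 3 sits at a limit, > 100000 nM, so that step marks only a bound and not a full size: the limit of > 100000 nM in this assay, at which 2 of the 3 values shown sit. Among the compounds shown, only compound 2, with its 4-hydroxyphenyl group, gives an actual number.

The compounds shown leave open whether hydroxy itself is needed here or whether another group, such as an amine or a methoxy group, would also keep a measurable value.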